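A Methoxy Group Added to Compound 2

This account rests on a few compounds, and the source may have more. Where it says the series, first, only, none or still open, it means among the compounds named here.

In a functional assay on MCF7 cells (Homo sapiens) for cytotoxicity, read by MTT assay, with a stated time of 48 h (on this read-out higher numbers stand for weaker inhibition and lower numbers for stronger inhibition), two related compounds have been measured so far. Compound 1 (`O=C(N/N=C/c1c[nH]c2ccc(Br)cc12)C(=O)c1c[nH]c2ccccc12`) gives 3300 nM and compound 2 (`O=C(N/N=C/c1c[nH]c2ccccc12)C(=O)c1cn(Cc2ccc(Cl)cc2)c2ccccc12`) gives 800 nM as the lower of the two numbers. The gap between them lies beyond the usual scatter of repeated measurements, so compound 2 is the stronger inhibitor of this pair. These two compounds differ in more than one place, and their gap cannot be tied to any single change.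

Compound 3 (`COc1ccc2[nH]cc(/C=N/NC(=O)C(=O)c3cn(Cc4ccc(Cl)cc4)c4ccccc34)c2c1`) has not yet been measured. It differs from compound 2 in one place: methoxy in place of hydrogen on an aromatic carbon. In words, this is methoxy in place of hydrogen on an aromatic carbon. For the measured compounds named here, no measured pair shows what this change does, so the expectation starts from compound 2 at 800 nM and stays cautious. The estimated 1.3-fold lower number from compound 2 to compound 3 (0.12 log units; within the scatter) in this assay is slightly downward and is not expected to exceed the scatter. For compound 3 the expected value is 600 nM, with an estimated range from 200 nM to 1800 nM.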

Compound 3, half-maximal inhibitory concentration: 3800 nM
Compound 3: middle estimate off by 6.3-fold (0.80 log units), on the low side, outside the stated range (above it).
By their numbers in this assay, from the lowest: compound 2; then compounds 1 and 3 (each within the scatter of the next).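

Replacing hydrogen with methoxy, which turns 1H-indol-3-yl into 5-methoxy-1H-indol-3-yl, gives a 4.8-fold higher number from compound 2 to compound 3 (0.68 log units; beyond the scatter) in this assay. For the compounds shown here, this is the first step that can be tied to a single change, and since higher numbers here stand for weaker inhibition, it shows that this aromatic carbon is sensitive to substitution and that methoxy at this place costs activity rather than leaving it unchanged. No supporting measurement is available to explain why the number rises with this change.

Going by these compounds, a single step at a single carbon cannot separate an effect of methoxy itself from what any added group might do here, so it remains open whether fluorine, a hydroxyl group or a longer chain such as ethoxy on the same carbon would also raise the number. On these data alone, it is equally open whether methoxy on another carbon of this ring, or the same change made on the core of compound 1, would give a step of similar size.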